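Chain Lengthening on Two Related Cores

The source may hold more compounds than are shown below. What is called first, only, known or untested is meant among the compounds shown, and "the series" means these compounds.

Measured compounds:
compound 1 `CCCCc1cc2ccccc2nc1-c1cc(-c2ccccc2)no1`: > 100000 nM (a limit of the assay)
compound 2 `CCCCCc1cc2ccccc2nc1-c1cc(-c2ccccc2)no1`: 92300 nM
compound 3 `CCc1cc2ccccc2nc1-c1cc(-c2ccc(C(F)(F)F)cc2)no1`: > 100000 nM (a limit of the assay)

In a functional assay on A549 cells (Homo sapiens) for inhibition, read by MTT assay, with a stated time of 24 h (a lower number here means a stronger inhibitor, a higher number a weaker inhibitor), compound 1 gives > 100000 nM, which is a limit of the assay rather than a number. Compound 2 gives 92300 nM in this assay. an at least 1.0-fold lower number from compound 1 to compound 2 (0.03 log units; that floor lies within the scatter); the change is methyl in place of hydrogen on a saturated chain carbon, four bonds along the chain from an aromatic carbon. Two of the three values sit at the limit of > 100000 nM in this assay, at which 2 of the 3 values shown sit. Compound 3 gives > 100000 nM, again a limit. How the core of compound 3 differs from the core of compound 1 is not broken down here.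

Compound 4 `CCCc1cc2ccccc2nc1-c1cc(-c2ccc(C(F)(F)F)cc2)no1` is not yet measured and differs from compound 3 by methyl in place of hydrogen on a saturated chain carbon, two bonds along the chain from an aromatic carbon. This is the same kind of change as that made from compound 1 to compound 2, but at a different place: two bonds along the chain from an aromatic carbon rather than four. Resting on an at least 1.0-fold lower number from compound 1 to compound 2 (0.03 log units; that floor lies within the scatter), the expected step is a number no higher from compound 3 to compound 4 (the limit leaves the size open). Compound 4 is therefore estimated at 100000 nM, between 50000 nM and 300000 nM, with a limit again likely.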

Compound 4, half-maximal inhibitory concentration: 43900 nM
For compound 4 the middle estimate is 2.3-fold (0.36 log units) above the measured one; measured number outside the range, below it.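

In this assay the methyl in place of hydrogen, on a saturated chain carbon two bonds along the chain from an aromatic carbon, gives an at least 2.2-fold lower number from compound 3 to compound 4 (0.35 log units; beyond the scatter). For the compounds shown here, the same kind of change, made at a different place on the chain of the other core, raises the number on neither core, but only this new step lies beyond the scatter. What the pairs do not show is whether the size of the step carries over from one core to the other, since both starting compounds sit at a limit: the same change on two cores in this assay, an at least 1.0-fold lower number (0.03 log units; that floor lies within the scatter) from compound 1 to compound 2 and an at least 2.2-fold lower number (0.35 log units; beyond the scatter) from compound 3 to compound 4; the limit leaves it open whether they differ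

The compounds shown leave open how a longer chain on the core of compound 3, or an amine or a carboxylic acid in its place, would read in this assay. They also leave open what the trifluoromethyl group contributes on its own, as no pair shown differs in that group alone.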